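Swapping Chloro for Trifluoromethyl in Compound 2

The source may hold more compounds than are shown below. What is called first, only, known or untested is meant among the compounds shown, and "the series" means these compounds.

Compound 1 `COc1cc(-c2nn(-c3cccc(NC(=O)Nc4ccc(Cl)c(Cl)c4)c3)cc2-c2ccncc2)ccc1Cl` gives 20300 nM in a functional assay on SF-268 cells (Homo sapiens) for inhibition, read by sulforhodamine B assay, with a stated time of 48 h; a higher number here means a weaker inhibitor of growth, a lower number a stronger inhibitor of growth.
Compound 2 `O=C(Nc1cccc(-n2cc(-c3ccncc3)c(-c3ccc(Cl)c(O)c3)n2)c1)Nc1ccc(Cl)c(Cl)c1` gives 10900 nM.
Compound 3 `COc1cc(-c2nn(-c3cccc(NC(=O)c4ccc(Cl)c(C(F)(F)F)c4)c3)cc2-c2ccncc2)ccc1Cl` is reported only as a limit, > 32500 nM.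

Of the two real numbers, compound 2 sits within the scatter of compound 1, the gap being a 1.9-fold lower number from compound 1 to compound 2 (0.27 log units; within the scatter), so neither can be called the stronger. The third value, for compound 3, is a limit of the assay the limit of > 32500 nM in this assay, at which 1 of the 3 values shown sits, and not a number.

Compound 4 `O=C(Nc1cccc(-n2cc(-c3ccncc3)c(-c3ccc(Cl)c(O)c3)n2)c1)Nc1ccc(Cl)c(C(F)(F)F)c1` differs from compound 2 by trifluoromethyl in place of chloro on an aromatic carbon. The closest measured step is an at least 1.6-fold higher number from compound 1 to compound 3 (0.20 log units; that floor lies within the scatter), which also swaps chloro for trifluoromethyl but removes the amino link at the same time, and its floor lies within the scatter. That step hints at a slightly higher number at most. In this assay the step from compound 2 to compound 4 is therefore expected to be small, a 1.3-fold higher number from compound 2 to compound 4 (0.11 log units; within the scatter), with no clear change beyond the scatter. Compound 4 is estimated at 14000 nM, between 5000 nM and 40000 nM.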

Compound 4, concentration for total growth inhibition: 6980 nM
For compound 4 the middle estimate is 2.0-fold (0.30 log units) above the measured one; measured number inside the range.
By their numbers in this assay, from the lowest: compounds 4, 2 and 1 (each within the scatter of the next, the first and the last beyond it). At a limit, above all of these: compound 3.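

The earlier step that brought in trifluoromethyl also removed the amino link, so it could not show what the new group does alone. Here the amino link stays and only the group on the aromatic carbon changes: in this assay the swap gives a 1.6-fold lower number from compound 2 to compound 4 (0.19 log units; within the scatter) and leaves compound 2 and compound 4 indistinguishable, so on this compound chloro and trifluoromethyl can stand in this place with no change that rises above the scatter. Nothing measured here explains why the swap makes so little difference.

Still open, from the compounds shown here alone, is whether this holds for very different groups in the same place, such as a nitrile, an amine or a carboxylic acid. Going by these compounds, it is also open whether the same swap would behave alike on compound 1, which carries a methoxy group where compound 2 carries a hydroxyl.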